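Aryl group on sulfur in the growth inhibition series

The source may hold more compounds than are shown below. What is called first, only, known or untested is meant among the compounds shown, and "the series" means these compounds.

In a functional assay on HeLa cells (Homo sapiens) for inhibition, read by CCK-8 assay, with a stated time of 72 h, tested at 8 uM (a lower number here means less inhibition of growth, a higher number more inhibition of growth at the concentration tested), compound 2 (`Nc1ccccc1NC(=O)c1ccc(CSc2cccc(F)c2)cc1`) gives 78.4%. Compound 1 (`CCc1ccc(SCc2ccc(C(=O)Nc3ccccc3N)cc2)cc1`) gives 71%. Within the data shown here, the only measured step is a number 7.4 percentage points higher from compound 1 to compound 2 (within the scatter), so these two numbers set no order between the compounds, and compound 2 stands level with compound 1 on the data so far.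

Compound 3 (`Cc1ccc(SCc2ccc(C(=O)Nc3ccccc3N)cc2)cc1`) has not yet been measured in this assay. The change from compound 2 is 4-methylphenyl in place of 3-fluorophenyl on a sulfur.

Among the measured compounds shown here, one measured step bears on this change, as it exchanges groups at the same sulfur: a number 7.4 percentage points higher from compound 1 to compound 2 (within the scatter). That step gives no ground for expecting a shift beyond the scatter. Compound 1 carries 4-ethylphenyl on that sulfur and gives 71%, so the expectation leans slightly towards that value. The expected change is a number 5.4 percentage points lower from compound 2 to compound 3 (within the scatter), a small downward one that stays within the scatter. For compound 3 the estimated value is 73%, with an expected range of 62% to 84%.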

Compound 3, percent growth inhibition at one concentration: 79.2%
For compound 3 the middle estimate is 6.2 percentage points below the measured one; measured number inside the range.
By their numbers in this assay, from the lowest: compounds 1, 2 and 3 (each within the scatter of the next).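

In this assay, the exchange of 3-fluorophenyl for 4-methylphenyl on the sulfur gives a number 0.8 percentage points higher from compound 2 to compound 3 (within the scatter), so these two aryl groups cannot be separated at the concentration tested, although one carries fluorine and the other a methyl group. The second new pair is the closer comparison at this position: going from 4-ethylphenyl to 4-methylphenyl, with hydrogen in place of methyl on a saturated chain carbon bound to an aromatic carbon, gives a number 8.2 percentage points higher from compound 1 to compound 3 (within the scatter), so shortening the chain by that one carbon also sets no order. With all three steps now inside the scatter, the series shows no trend at this sulfur, and no measurement offered here speaks to why the three aryl groups read alike.

Still open, on these data alone, is whether a more different group on the phenyl ring, such as an amine, a carboxylic acid or a longer chain than ethyl, would move the number beyond the scatter. A reading at a single concentration also leaves open whether compounds this close would separate in a full concentration series.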